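This account rests on a few compounds, and the source may have more. Where it says the series, first, only, none or still open, it means among the compounds named here.

Compound 2, with the structure `CC#CCn1c(N2CCC[C@@H](N)C2)cc(=O)n(Cc2cc(C(=O)O)ccc2Br)c1=O`, stands in an assay on isolated protein for inhibition of Dipeptidyl peptidase 9 (Homo sapiens), read by fluorescence, with stated times of 15 min and 20 min (a higher number here means a weaker inhibitor, a lower number a stronger inhibitor), only at a limit. In this assay compound 2 gives > 100 nM, which is a limit of the measurement and not a number. Its closest measured neighbour, compound 1, with the structure `CC#CCn1c(N2CCC[C@@H](N)C2)cc(=O)n(Cc2cc(C(=O)OC)ccc2Br)c1=O`, is likewise known only at a limit. In this assay compound 1 gives > 100 nM, again a limit. The step that the two limits leave unreadable from compound 1 to compound 2 therefore cannot be read in size or direction. Compound 3, with the structure `CC#CCn1c(N2CCC[C@@H](N)C2)cc(=O)n(Cc2ccc(Br)c(C(=O)OC)c2)c1=O`, also sits at a limit. In this assay compound 3 gives > 100 nM, a limit as well. Taken together, (the limit of > 100 nM in this assay, at which 3 of the 3 values shown sit), so none of the measured values gives a foothold for a real number.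

Compound 4, with the structure `CC#CCn1c(N2CCC[C@@H](N)C2)cc(=O)n(Cc2ccc(F)c(C(=O)O)c2)c1=O`, differs from compound 2 in one place: 3-carboxy-4-fluorophenyl in place of 2-bromo-5-carboxyphenyl on a saturated chain carbon bound to an aromatic nitrogen. Among the compounds with values here, no measured step bears on this change in a readable way, since every step among compounds 1, 2 and 3 runs between limits. With nothing to point either way, compound 4 is expected to stay near the same limit, an estimated step that the limit leaves unreadable from compound 2 to compound 4. The estimate for compound 4 in this assay is 300 nM, within a range from 100 nM to 3000 nM.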

Compound 4, half-maximal inhibitory concentration: > 100 nM
Compound 4: no number, only a limit; the forecaster's own chance of this, stated with the estimate: 70%; the middle value does not contradict the limit.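

In this assay compound 4 gives > 100 nM as a limit, not a number. Compound 2 also stands only at a limit, and the step between compound 2 and compound 4 cannot be read in size or direction. The compounds shown leave open how strongly each one inhibits the enzyme, and whether 3-carboxy-4-fluorophenyl in place of 2-bromo-5-carboxyphenyl changes that at all.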